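The source may hold more compounds than are shown below. What is called first, only, known or untested is meant among the compounds shown, and "the series" means these compounds.

Three compounds have been measured so far:
compound 1 `O=C1C=C(Nc2ccc(I)cc2)C(=O)c2c1nc1n2[C@H]2OC[C@@H](O)[C@H]2OC1` gives 2300 nM in a functional assay on ECa-109 cells for inhibition, with ECa-109 cell line (Homo sapiens) as the target, read by sulforhodamine B assay; on this read-out lower numbers stand for stronger inhibition and higher numbers for weaker inhibition;
compound 2 `Cc1ccc(NC2=CC(=O)c3nc4n(c3C2=O)[C@H]2OC[C@@H](O)[C@H]2OC4)cc1C` gives 2820 nM;
compound 3 `COc1cccc(NC2=CC(=O)c3nc4n(c3C2=O)[C@H]2OC[C@@H](O)[C@H]2OC4)c1` gives 7620 nM.

Compound 3 has the highest number of the three, which on this read-out means the weakest inhibition. Both of its neighbours lie beyond the scatter below it: the step of a 3.3-fold higher number from compound 1 to compound 3 (0.52 log units; beyond the scatter) and the step of a 2.7-fold higher number from compound 2 to compound 3 (0.43 log units; beyond the scatter) each mark a modest loss on arriving at the 3-methoxyphenyl group.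

Compound 4 `O=C1C=C(Nc2ccccc2)C(=O)c2c1nc1n2[C@H]2OC[C@@H](O)[C@H]2OC1` differs from compound 3 in one place: hydrogen in place of methoxy on an aromatic carbon. Going by the values given here, no measured step removes a group from this ring without putting another in its place, so the two known steps bear on the change only indirectly. They show that the 3-methoxyphenyl compound sits highest, while compounds carrying 4-iodophenyl or 3,4-dimethylphenyl sit lower; what a bare phenyl does is not shown by any pair.

With the methoxy gone, compound 4 is expected to give a somewhat lower number than compound 3. The step of a 1.4-fold lower number from compound 3 to compound 4 (0.14 log units; within the scatter) is expected to remain within the scatter. Compound 4 is therefore estimated at 5500 nM, with a range from 2200 nM to 14000 nM.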

Compound 4, half-maximal inhibitory concentration: 4970 nM
For compound 4 the middle estimate is 1.1-fold (0.04 log units) above the measured one; the range from low to high includes it.
By their numbers in this assay, from the lowest: compounds 1, 2, 4 and 3 (each within the scatter of the next, the first and the last beyond it).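

In this assay, compound 4 supplies the first ring with no added group, so the groups on this ring can now be set against plain hydrogen. Removing the methoxy, a 1.5-fold lower number from compound 3 to compound 4 (0.19 log units; within the scatter), stays within the scatter, as does phenyl in place of 3,4-dimethylphenyl, a 1.8-fold higher number from compound 2 to compound 4 (0.25 log units; within the scatter), so neither group can be told apart from hydrogen here, although compound 2 and compound 3 do differ from each other. Going by these compounds alone, only hydrogen in place of iodo, a 2.2-fold higher number from compound 1 to compound 4 (0.33 log units; beyond the scatter), goes beyond the scatter, a modest weakening of inhibition that makes the iodo the one group here with a readable gain over hydrogen, and nothing available explains that gain.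

The compounds shown leave open whether this small gain belongs to iodo alone or would also appear with another halogen, such as chloro or bromo, on the ring. They also leave open whether a quite different group there, such as an amine or a carboxylic acid, would move the number by more than these modest steps.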